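This account rests on a few compounds, and the source may have more. Where it says the series, first, only, none or still open, it means among the compounds named here.

Compound 1, `Cc1cc(Nc2cc(-c3ccccc3)[nH]n2)n2nc(SCc3ccc(F)cc3)nc2n1`, in a functional assay on PC-9 cells (Homo sapiens) for inhibition, read by MTT assay, with a stated time of 72 h; a lower number here means a stronger inhibitor, a higher number a weaker inhibitor: 8110 nM
Compound 2, `Cc1cc(Nc2cc(-c3ccccc3)[nH]n2)n2nc(SCc3c(Cl)cccc3Cl)nc2n1`, in this assay: 5180 nM
Compound 3, `Cc1cc(Nc2cc(-c3ccccc3)[nH]n2)n2nc(SCc3ccc([N+](=O)[O-])cc3)nc2n1`, in this assay: 7980 nM

All three compounds share one core and differ only in the group carried on a saturated chain carbon bound to a sulfur. Compound 3 gives the second highest of the three numbers; its nearest neighbour is compound 1 and its furthest is compound 2, and both gaps fall within the scatter of the measurement, so the three compounds cannot be told apart on these numbers. Compound 4, `Cc1cc(Nc2cc(-c3ccccc3)[nH]n2)n2nc(SCC3CCCCC3)nc2n1`, has not yet been measured. It differs from compound 3 in one place: cyclohexyl in place of 4-nitrophenyl on a saturated chain carbon bound to a sulfur. The measured steps that bear on this change are the earlier swaps at the same position: a 1.6-fold lower number from compound 1 to compound 2 (0.19 log units; within the scatter), a 1.0-fold lower number from compound 1 to compound 3 (0.01 log units; within the scatter) and a 1.5-fold higher number from compound 2 to compound 3 (0.19 log units; within the scatter). Each of these exchanged the group at this position and none moved the number beyond the scatter, so the expectation for this assay is a step of no more than the scatter, in either direction. Compound 4 is therefore expected to give about 8000 nM, within a range from 3000 nM to 20000 nM. This corresponds to an expected step of a 1.0-fold higher number from compound 3 to compound 4 (0.00 log units; within the scatter).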

Compound 4, half-maximal inhibitory concentration: > 50000 nM
Compound 4: a limit, no number; the forecaster's own chance of this, stated with the estimate: 10%; at least 6.2-fold (0.79 log units) between middle value and limit.
By their numbers in this assay, from the lowest: compounds 2, 3 and 1 (each within the scatter of the next). At a limit, above all of these: compound 4.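

Until now the group on the saturated chain carbon bound to a sulfur could be exchanged among 4-fluorophenyl, 2,6-dichlorophenyl and 4-nitrophenyl, all aromatic rings, with no step beyond the scatter, so the position looked tolerant of change. Cyclohexyl, the one non-aromatic ring among the four compounds, breaks that picture, with an at least 6.2-fold higher number from compound 3 to compound 4 (0.79 log units; beyond the scatter) and an at least 9.6-fold higher number from compound 2 to compound 4 (0.98 log units; beyond the scatter) as well as an at least 6.1-fold higher number from compound 1 to compound 4 (0.78 log units; beyond the scatter) in the same direction, so the group here does matter for this cell read-out. The value of compound 4 in this assay is a limit and not a number, so these steps give only the smallest possible size of the change: the limit of > 50000 nM in this assay, at which 1 of the 4 values shown sits.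

With a single non-aromatic group, the compounds shown cannot separate the loss of the aromatic ring from anything else that differs between 4-nitrophenyl and cyclohexyl, and they do not show how far the true value of compound 4 lies past the limit. A longer chain or an amine at this position would show whether the drop belongs to cyclohexyl alone or extends to other groups without an aromatic ring.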